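The source may hold more compounds than are shown below. What is called first, only, known or untested is meant among the compounds shown, and "the series" means these compounds.

Series notes. In a functional assay on SMMC-7721 cells (Homo sapiens) for inhibition, read by MTT assay, with a stated time of 72 h, tested at 25 uM (on this read-out higher numbers stand for more inhibition at the one concentration tested (going by the name of the read-out) and lower numbers for less inhibition), compound 1 `Cc1nn(C)c(Oc2ccc(Cl)cc2)c1/C=N\OCc1c(Cl)c(-c2ccc(F)cc2)nn1C` gives 80%. In this assay compound 2 `COc1ccc(Oc2c(/C=N\OCc3c(Cl)c(-c4ccc(F)cc4)nn3C)c(C)nn2C)cc1` gives 80%. In this assay compound 3 `Cc1nn(C)c(Oc2ccc(OC(F)(F)F)cc2)c1/C=N\OCc1c(Cl)c(-c2ccc(F)cc2)nn1C` gives 80%. Compound 2 thus stands level with compounds 1 and 3 at the digits shown; the steps of no change at the digits printed from compound 1 to compound 2 (within the scatter), no change at the digits printed from compound 1 to compound 3 (within the scatter) and no change at the digits printed from compound 2 to compound 3 (within the scatter) all lie within the scatter. Compound 4 `CCc1nn(C)c(CO/N=C\c2c(C)nn(C)c2Oc2ccc(OC)cc2)c1Cl` differs from compound 2 by ethyl in place of 4-fluorophenyl on an aromatic carbon. Within the data shown here, none of the three measured steps touches the place of this change, so they give no direct guide; the flat series shows only that changes elsewhere did not move the read-out. A modest fall with a wide range is therefore expected for compound 4, which is estimated at 60% (range 25% to 90%), the expected step being a number 20 percentage points lower from compound 2 to compound 4 (beyond the scatter).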

Compound 4, a percentage reported as inhibition, at one concentration (the size of the read-out at that concentration, not a potency): < 80%
Compound 4 was reported as a limit; the forecaster's own chance of this, stated with the estimate: 0%; the middle value is on the limit's open side.
By their numbers in this assay, from the lowest: compounds 1, 2 and 3 (each within the scatter of the next).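

In this assay compound 4 is recorded only as a limit, < 80%. Ethyl in place of 4-fluorophenyl on this aromatic carbon gives a number no higher from compound 2 to compound 4 (the limit leaves the size open). Among these compounds, this is the first step at this position, as the three earlier steps lay elsewhere in the molecule, and it shows only that this exchange brought no rise in the read-out, not whether there was a real fall. The compounds shown leave open the size of this step, and how an unsubstituted phenyl, a longer chain or an amine would read on this aromatic carbon.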